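A Fluoro Addition on the Aryl Ring of Compound 2

The compounds below may be only part of what the source reports. "The series", "measured", "known", "first", "only" and "open" are said of these compounds alone.

Compound 2 `CN(C)C(=O)c1cc2cnc(Nc3ccc(C(=O)NCCCN=C=S)cc3)nc2n1C1CCCC1` gives 32.9% in a functional assay on A549 cells (Homo sapiens) for inhibition, read by CCK-8 assay, with a stated time of 72 h, tested at 1 uM (a lower number here means a weaker effect, a higher number a stronger effect of the compound at the concentration tested), the second highest of three numbers: compound 1 `CN(C)C(=O)c1cc2cnc(Nc3ccc(S(=O)(=O)NCCCN=C=S)cc3)nc2n1C1CCCC1` gives 58.9%, and compound 3 `CN(C)C(=O)c1cc2cnc(Nc3ccc(C(=O)NCCCCN=C=S)cc3)nc2n1C1CCCC1` gives 30.2%, the latter within the scatter of compound 2. The new compound 4 `CN(C)C(=O)c1cc2cnc(Nc3ccc(C(=O)NCCCN=C=S)cc3F)nc2n1C1CCCC1` differs from compound 2 by fluoro in place of hydrogen on an aromatic carbon. Among the measured compounds shown here, none of the measured steps involves a fluoro group; the steps of a number 26 percentage points lower from compound 1 to compound 2 (beyond the scatter) and a number 28.7 percentage points lower from compound 1 to compound 3 (beyond the scatter) swap out a whole linker, and the step of a number 2.7 percentage points lower from compound 2 to compound 3 (within the scatter) lengthens a chain with no change beyond the scatter. For the measured compounds named here, with no direct precedent, the expected step of a number 0.1 percentage points higher from compound 2 to compound 4 (within the scatter) is none beyond the scatter. Compound 4 is therefore estimated at 33%, ranging from 18% to 50%.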

Compound 4, a percentage reported as inhibition, at one concentration (the size of the read-out at that concentration, not a potency): 16.7%
Compound 4: the middle estimate sits 16.3 percentage points above what was measured, outside the stated range (below it).
By their numbers in this assay, from the lowest: compound 4; then compounds 3 and 2 (each within the scatter of the next); then compound 1.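

In this assay, fluoro in place of hydrogen, ortho to a large group, gives a number 16.2 percentage points lower from compound 2 to compound 4 (beyond the scatter). This aromatic carbon is therefore sensitive to a single added atom, whereas the chain lengthening gave only a number 2.7 percentage points lower from compound 2 to compound 3 (within the scatter). Nothing shown explains the loss.

Still open, from the compounds shown here alone, is whether the drop is specific to fluoro or would follow any group on this carbon, which chloro, methyl or methoxy there could help separate. Also open, going by these compounds, is whether the same fluoro would cost as much on compound 1.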